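The source may hold more compounds than are shown below. What is called first, only, known or untested is meant among the compounds shown, and "the series" means these compounds.

Working notes on the series. Compound 3 `Nc1nc(-c2ccco2)cc(-c2ccccc2O)n1` carries furan-2-yl on the shared core; in an ADME assay on MT4 cells (Homo sapiens) for cytotoxicity, read by MTT assay, with a stated time of 5 days (a lower number here means that less compound is tolerated, a higher number that more compound is tolerated), compound 3 gives > 125000 nM, which is a limit of the assay and not a number. Compound 1 `Nc1nc(-c2ccc(F)cc2)cc(-c2ccccc2O)n1` in this assay gives 67500 nM. Compound 2 `Nc1nc(-c2ccc(Cl)cc2)cc(-c2ccccc2O)n1` in this assay gives > 74700 nM, a limit of the assay. For the measured compounds named here, the steps of an at least 1.8-fold higher number from compound 1 to compound 3 (0.26 log units; that floor lies within the scatter) and a step that the two limits leave unreadable from compound 2 to compound 3 are the only ones reaching compound 3, which alone sits at the limit of > 125000 nM in this assay, at which 1 of the 3 values shown sits. Compound 4 `Nc1nc(-c2cccs2)cc(-c2ccccc2O)n1` differs by thiophen-2-yl in place of furan-2-yl on an aromatic carbon. Going by the values given here, no measured step exchanges one five-membered aromatic ring for another, and the nearest step an at least 1.8-fold higher number from compound 1 to compound 3 (0.26 log units; that floor lies within the scatter) lies within the scatter. The step of an at least 1.1-fold lower number from compound 3 to compound 4 (0.05 log units; that floor lies within the scatter) is therefore expected to stay within the scatter. Compound 4 is estimated at 110000 nM, between 50000 nM and 250000 nM, with a limit quite possible.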

Compound 4, half-maximal cytotoxic concentration: 5300 nM
Beside the measured number, compound 4's estimate is 21-fold (1.32 log units) above it; the whole stated range lies above it.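

In this assay, the position opposite the ring nitrogen turns out to respond strongly to the hetero atom of a five-membered aromatic ring: sulfur in place of oxygen gives an at least 23-fold lower number from compound 3 to compound 4 (1.37 log units; beyond the scatter). Thiophen-2-yl also stands apart from both phenyl groups, with an at least 14-fold lower number from compound 2 to compound 4 (1.14 log units; beyond the scatter) and a 13-fold lower number from compound 1 to compound 4 (1.11 log units; beyond the scatter), whereas the earlier steps here lay within the scatter or could not be read. Nothing measured in the series accounts for this change.

As far as these compounds go, whether other rings at this position, such as thiazole or pyridine, follow thiophen-2-yl or furan-2-yl stays open. So does the effect of a methyl group or a carboxylic acid on the thiophene ring.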